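Dimethylamino in Place of Methyl: the Next Step

The source may report more compounds than this note shows. Statements on the series, on what has been measured and on what is new or still open speak of the compounds shown alone.

Compound 1, `O=C(Nc1ccc(-c2ccccc2)cn1)Oc1ccccc1`, gives 0% in an assay on isolated protein (Aquatica lateralis) for inhibition of Luciferin 4-monooxygenase (Luciola lateralis), read by a luciferase reporter, tested at 10 uM; a lower number here means less inhibition, a higher number more inhibition at the concentration tested (going by the name of the read-out). Compound 2, `O=C(Nc1ccc(-c2ccccc2)cn1)c1ccc(Cl)cc1`, gives 0% in this assay. Compound 3, `Cc1ccc(C(=O)Nc2ccc(-c3ccccc3)cn2)cc1`, gives 18% in this assay.

Compound 3 stands highest of the three numbers: its nearest neighbour is compound 1, a number 18 percentage points higher from compound 1 to compound 3 (beyond the scatter), and its furthest is compound 2, a number 18 percentage points higher from compound 2 to compound 3 (beyond the scatter). Between compound 1 and compound 2 there is no change at the digits printed from compound 1 to compound 2 (within the scatter). Compound 4, `CN(C)c1ccc(C(=O)Nc2ccc(-c3ccccc3)cn2)cc1`, has not yet been measured. Compared with compound 3 it shows (dimethylamino in place of methyl on an aromatic carbon).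

Within the data shown here, two measured steps bear on this change. The step from compound 2 to compound 3 swaps one group for another at the same aromatic carbon and moved the number modestly, a number 18 percentage points higher from compound 2 to compound 3 (beyond the scatter). The step from compound 1 to compound 3 was of the same size. Each change among the measured compounds moved the read-out by a modest amount or not at all, so the change from compound 3 to compound 4 is expected to do the same: compound 4 is expected to sit close to compound 3, the estimated step being a number 3 percentage points lower from compound 3 to compound 4 (within the scatter). The estimate for compound 4 in this assay is 15%, with a range from 0% to 40%.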

Compound 4, a percentage reported as inhibition, at one concentration (the size of the read-out at that concentration, not a potency): 35%
The estimate for compound 4 lay 20 percentage points below the measured number; low and high end bracket the measured number.
By their numbers in this assay, from the lowest: compounds 1 and 2 (each within the scatter of the next); then compound 3; then compound 4.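

At the aromatic carbon para to a large group, this assay now separates three substituents, and moving from methyl to dimethylamino gives a number 17 percentage points higher from compound 3 to compound 4 (beyond the scatter). With chloro at that same carbon as the reference, the change to dimethylamino gives a number 35 percentage points higher from compound 2 to compound 4 (beyond the scatter), the first large step in the series, whereas the earlier compounds had shown only modest steps or none; together with a number 18 percentage points higher from compound 2 to compound 3 (beyond the scatter), this places chloro, methyl and dimethylamino in rising order across these three compounds alone, with none of them going against that order. The data on hand offer no measurement that accounts for this order.

On these data alone, whether the rise continues with a larger group at this carbon, such as diethylamino or a morpholine ring, or whether a primary amine or a methoxy group there would give a similar number, remains open. Among these compounds, also open is how compound 4 would behave across a range of concentrations, since its single reading at one concentration gives the size of the inhibition and not a potency.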